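A New Aryl Group on the Ring-Bound Nitrogen

The source may report more compounds than this note shows. Statements on the series, on what has been measured and on what is new or still open speak of the compounds shown alone.

Measured so far:
compound 1 `COc1cc(NC(=O)Nc2cc(Nc3ccc(C(C)(C)C)cc3)ncn2)cc(OC)c1`: 74.1%
compound 2 `CC(C)(C)c1ccc(Nc2cc(NC(=O)Nc3c(Cl)cccc3Cl)ncn2)cc1`: 41.5%

In a functional assay on PC-9 cells (Homo sapiens) for inhibition, read by MTT assay, with a stated time of 48 h, tested at 10 uM (a higher number here means more inhibition at the concentration tested (going by the name of the read-out), a lower number less inhibition), compound 1 stands highest of the two numbers. Within the data shown here, the only measured step, a number 32.6 percentage points lower from compound 1 to compound 2 (beyond the scatter), is large, but it alters the group on the amide-type nitrogen. Compound 3 `COc1cc(NC(=O)Nc2cc(Nc3cc(I)ccc3OC)ncn2)cc(OC)c1` differs from compound 1 elsewhere: 5-iodo-2-methoxyphenyl in place of 4-(tert-butyl)phenyl on a nitrogen on an aromatic ring. Among the measured compounds shown here, no measured step touches that position, so none bears directly on this change, and its direction cannot be read from the data. A moderate drop is estimated, a number 19.1 percentage points lower from compound 1 to compound 3 (beyond the scatter). Compound 3 is therefore expected to give 55%, likely between 25% and 85%.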

Compound 3, a percentage reported as inhibition, at one concentration (the size of the read-out at that concentration, not a potency): 91%
Compound 3: the middle estimate sits 36 percentage points below what was measured; measured number above the stated range.
By their numbers in this assay, from the lowest: compound 2; then compound 1; then compound 3.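

The position on the nitrogen on an aromatic ring clearly affects the result: in this assay, 5-iodo-2-methoxyphenyl in place of 4-(tert-butyl)phenyl gives a number 16.9 percentage points higher from compound 1 to compound 3 (beyond the scatter) while the rest of the molecule stays the same. So among these compounds, the 4-(tert-butyl)phenyl group is not needed for strong inhibition at this position. No supporting measurement explains the rise.

From the compounds shown here alone, the iodine and the methoxy group arrived together, so their separate contributions remain unknown. Going by these compounds, it is also open whether a bromine in place of the iodine, or an amine in place of the methoxy group, would keep this level of inhibition.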